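Halogen Swaps on the Benzyl Group and Cell Growth

The compounds below may be only part of what the source reports. "The series", "measured", "known", "first", "only" and "open" are said of these compounds alone.

Compound 1 `O=c1ccoc2cc(OCc3cn(Cc4cccc(Br)c4)nn3)ccc12`: > 100000 nM
Compound 2 `O=c1ccoc2cc(OCc3cn(Cc4ccc(Cl)cc4Cl)nn3)ccc12`: > 100000 nM

In a functional assay on MDA-MB-231 cells (Homo sapiens) for cytotoxicity, read by MTT assay, with a stated time of 48 h (a higher number here means a weaker inhibitor, a lower number a stronger inhibitor), compound 1 gives > 100000 nM, a limit of the assay rather than a number. Compound 2 likewise gives > 100000 nM, again a limit. The step that the two limits leave unreadable from compound 1 to compound 2 is therefore unreadable, and both values rest at the limit of > 100000 nM in this assay, at which 2 of the 2 values shown sit. Compound 3 `O=c1ccoc2cc(OCc3cn(Cc4cccc(F)c4)nn3)ccc12` differs from compound 2 by 3-fluorophenyl in place of 2,4-dichlorophenyl on a saturated chain carbon bound to an aromatic nitrogen. Within the data shown here, no measured step reads out on this change, so no movement beyond the scatter is expected, and the expected step of a number no higher from compound 2 to compound 3 (the limit leaves the size open) is small. Compound 3 is estimated at 100000 nM, between 30000 nM and 300000 nM.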

Compound 3, half-maximal inhibitory concentration: > 100000 nM
Compound 3: only a limit was reported; the forecaster's own chance of this, stated with the estimate: 80%; the middle value lies on the limit itself.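

No step can be read among compound 1, compound 2 and compound 3, because each gives only a limit, not a number: the limit of > 100000 nM in this assay, at which 3 of the 3 values shown sit.

The compounds shown leave open whether these halogen-bearing benzyl groups differ at all in this assay.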